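Shortening a Chain: One Measured Step, One Expected

A few compounds are considered here, and "the series" means these few. Any claim that something is new, unique, unknown or untested is made for them only; others in the source may bear on it.

Compound 1 `CCCCCCNC(=O)/C=C/c1ccccc1` is tested in a functional assay on the whole organism for inhibition, with Brassica rapa subsp. chinensis as the target, with a stated time of 3 days, tested at 100 ppm (on this read-out lower numbers stand for less inhibition of growth and higher numbers for more inhibition of growth at the one concentration tested), where compound 1 gives 55%. Compound 3 `CCCNC(=O)/C=C/c1ccccc1` gives 15% in this assay. The change between them is hydrogen in place of propyl on a saturated chain carbon, three bonds along the chain from an amide-type nitrogen, and it makes a step of a number 40 percentage points lower from compound 1 to compound 3 (beyond the scatter).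

Compound 2 `CCCCCOC(=O)/C=C/c1ccc(C(C)C)cc1` gives 29% in this assay. The difference between the core of compound 1 and the core of compound 2 is not broken down here. Compound 4 `CCOC(=O)/C=C/c1ccc(C(C)C)cc1` differs from compound 2 by hydrogen in place of propyl on a saturated chain carbon, two bonds along the chain from an oxygen next to a carbonyl group. This is the same kind of change as before, though the place differs: three bonds along the chain from an amide-type nitrogen in the first pair, two bonds along the chain from an oxygen next to a carbonyl group in the second.

Because the measured pair shows a number 40 percentage points lower from compound 1 to compound 3 (beyond the scatter), a downward step of a number 17 percentage points lower from compound 2 to compound 4 (beyond the scatter) is expected from compound 2 to compound 4. Compound 4 is therefore estimated at 12%, with an expected range from 0% to 35%.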

Compound 4, percent growth inhibition at one concentration: 44%
Compound 4: the middle estimate sits 32 percentage points below what was measured; measured number outside the range, above it.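

In this assay, the shorter chain gives a number 15 percentage points higher from compound 2 to compound 4 (beyond the scatter). The same change therefore moves the number in opposite directions on the two cores, so the result from one core cannot be carried over to the other in this series: the same change on two cores in this assay, a number 40 percentage points lower (beyond the scatter) from compound 1 to compound 3 and a number 15 percentage points higher (beyond the scatter) from compound 2 to compound 4, 55 percentage points apart, beyond the scatter of two such steps

For the compounds shown here, this does not show what lies behind the reversal, as the two pairs differ both in their cores and in the place of the change, and each core supplies only a single pair. The compounds shown leave open how a butyl chain or a longer chain such as octyl would behave on either core. They also leave open whether the number rises or falls steadily with chain length or peaks at some intermediate chain.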